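The source may report more compounds than this note shows. Statements on the series, on what has been measured and on what is new or still open speak of the compounds shown alone.

Compound 1 `CS/C(=N\C(=O)c1sccc1Cl)NC(=O)c1sccc1Cl` and compound 2 `CS/C(=N\C(=O)c1cc(-c2ccccc2)nc2ccccc12)NC(=O)c1cc(-c2ccccc2)nc2ccccc12` are built on different cores; how the two cores differ is not broken down here. In a functional assay on MCF7 cells (Homo sapiens) for cytotoxicity, read by MTT assay, with a stated time of 72 h (on this read-out higher numbers stand for weaker inhibition of growth and lower numbers for stronger inhibition of growth), compound 1 gives 57100 nM and compound 2 gives 87700 nM, two values within the usual scatter of each other. Compound 3 `C[Se]/C(=N\C(=O)c1cc(-c2ccccc2)nc2ccccc12)NC(=O)c1cc(-c2ccccc2)nc2ccccc12` carries the change (a group of 2 heavy atoms (1 carbon, 1 selenium; no ring) in place of a group of 2 heavy atoms (1 carbon, 1 sulfur; no ring), on a carbon with a double bond to nitrogen), and in this assay compound 3 gives 7520 nM, which is a 12-fold lower number from compound 2 to compound 3 (1.07 log units; beyond the scatter). Compound 4 `C[Se]/C(=N\C(=O)c1sccc1Cl)NC(=O)c1sccc1Cl` carries the same change on the core of compound 1, namely (a group of 2 heavy atoms (1 carbon, 1 selenium; no ring) in place of a group of 2 heavy atoms (1 carbon, 1 sulfur; no ring), on a carbon with a double bond to nitrogen). Compound 4 is expected to show a step of a 9.5-fold lower number from compound 1 to compound 4 (0.98 log units; beyond the scatter), because a 12-fold lower number from compound 2 to compound 3 (1.07 log units; beyond the scatter) was seen on the other core, although this rests on a single measured pair. Compound 4 is therefore estimated to give 6000 nM in this assay, likely between 2000 nM and 25000 nM.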

Compound 4, concentration for total growth inhibition: 31200 nM
For compound 4 the middle estimate is 5.2-fold (0.72 log units) below the measured one; the whole stated range lies below it.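

In this assay, putting the selenium group in place of methylsulfanyl on the core of compound 1 gives a 1.8-fold lower number from compound 1 to compound 4 (0.26 log units; within the scatter), so on this core the change cannot be told from scatter. The step seen on one core therefore did not carry over in size to the other: the same change on two cores in this assay, a 12-fold lower number (1.07 log units; beyond the scatter) from compound 2 to compound 3 and a 1.8-fold lower number (0.26 log units; within the scatter) from compound 1 to compound 4, 6.4-fold (0.80 log units) apart, beyond the scatter of two such steps

This shows that the size of the step differs in these two pairs, but it does not show which part of the cores accounts for that, and two pairs give no rule for any other core. From the compounds shown here alone, what an ethylsulfanyl group or an amine would give on the same carbon stays open. So does the size of the step on a third core.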